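This account rests on a few compounds, and the source may have more. Where it says the series, first, only, none or still open, it means among the compounds named here.

Of the compounds shown here, two of a shared core have been measured in a functional assay on U-87MG ATCC cells for antiproliferative activity against U-87 MG (Homo sapiens), read by MTT assay, with a stated time of 48 h, tested at 10 uM; a lower number here means a stronger effect, a higher number a weaker effect of the compound at the concentration tested. Compound 1, `Cc1nc(-c2ccc(Cl)cc2)sc1C(=O)CSc1nc(-c2ccc(Cl)c(Cl)c2)c(C#N)c(=O)[nH]1`, gives 97.1%. Compound 2, `Cc1nc(-c2ccccc2)sc1C(=O)CSc1nc(-c2ccc(Cl)cc2)c(C#N)c(=O)[nH]1`, gives 85.2%, which is the lower of the two numbers, and compound 1 stands higher by a gap beyond the usual scatter. Among the measured compounds shown here, the two differ in more than one place, so their values show only that the pair spans this gap. Compound 3, `Cc1nc(-c2ccc(Cl)cc2)sc1C(=O)CSc1nc(-c2ccc(Cl)cc2)c(C#N)c(=O)[nH]1`, differs from compound 2 in a single place: chloro in place of hydrogen on an aromatic carbon. For the measured compounds named here, no single-point step between measured compounds is available to guide the expectation. Since compound 1, which also carries a 4-chlorophenyl at this position, gives 97.1%, a modest upward step from compound 2 is expected, estimated as a number 4.8 percentage points higher from compound 2 to compound 3 (within the scatter), though it may not exceed the scatter. Compound 3 is therefore expected to give about 90%, within a range from 78% to 100%.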

Compound 3, a percentage reported as activity, at one concentration (the size of the read-out at that concentration, not a potency): 98.4%
Compound 3: middle estimate off by 8.4 percentage points, on the low side; low and high end bracket the measured number.
By their numbers in this assay, from the lowest: compound 2; then compounds 1 and 3 (each within the scatter of the next).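

In this assay, among the compounds shown here, the change from phenyl to 4-chlorophenyl gives the first single-place reading at this position: a number 13.2 percentage points higher from compound 2 to compound 3 (beyond the scatter), so adding chloro here weakens the effect at the tested concentration. The other six-membered aromatic ring behaves differently in this small set, since replacing one of its chloro groups with hydrogen gives a number 1.3 percentage points higher from compound 1 to compound 3 (within the scatter), a step that cannot be told from scatter. Nothing at hand explains either step.

The compounds shown leave open whether this weakening is particular to chloro, or whether a fluoro, methoxy or amino group in the same place would shift the read-out similarly. They also leave open whether the step from phenyl to 4-chlorophenyl would be of similar size on a core carrying a different second aromatic ring.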